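The source may report more compounds than this note shows. Statements on the series, on what has been measured and on what is new or still open speak of the compounds shown alone.

Compound 1 `O=C(CSc1ncc[nH]1)Nc1ccc2nc(NC(=O)c3ccc(C(F)(F)F)cc3)sc2c1`: 18800 nM
Compound 2 `Cc1cc(C)cc(C(=O)Nc2nc3ccc(NC(=O)CSc4ccc(Cl)cc4)cc3s2)c1`: > 100000 nM
Compound 3 `O=C(CSc1cccc(O)c1)Nc1ccc2nc(NC(=O)c3cc(Cl)cc(Cl)c3)sc2c1`: 1530 nM

All three readings come from a functional assay on U2OS cells (Homo sapiens) for antiproliferative activity, read by MTT assay, with a stated time of 72 h; on this read-out higher numbers stand for weaker inhibition and lower numbers for stronger inhibition. The entry for compound 2, > 100000 nM, is a limit of the assay and not a number. Of the two true numbers, the higher belongs to compound 1, at 18800 nM. Compound 3 gives a lower number, 1530 nM, and this gap lies beyond the scatter.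

Compound 4 `O=C(CSC1CCCCC1)Nc1ccc2nc(NC(=O)c3ccc(C(F)(F)F)cc3)sc2c1` keeps the rest of compound 1 and carries cyclohexyl in place of 1H-imidazol-2-yl on a sulfur. Among the compounds with values here, no measured pair differs in one place only, so this change has no direct precedent. In this assay, the expected outcome is no shift beyond the scatter, with a slight lean towards a higher number. The estimated 1.3-fold higher number from compound 1 to compound 4 (0.12 log units; within the scatter) reflects that expectation. The range is kept wide in view of the limit of > 100000 nM in this assay, at which 1 of the 3 values shown sits. For compound 4 the estimated value is 25000 nM, with an expected range of 5000 nM to 90000 nM.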

Compound 4, half-maximal inhibitory concentration: 12300 nM
Compound 4: the middle estimate sits 2.0-fold (0.31 log units) above what was measured, within the range that was stated.
By their numbers in this assay, from the lowest: compound 3; then compounds 4 and 1 (each within the scatter of the next). At a limit, above all of these: compound 2.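

In this assay, cyclohexyl in place of 1H-imidazol-2-yl on a sulfur gives a 1.5-fold lower number from compound 1 to compound 4 (0.18 log units; within the scatter). Within the data shown here, this is the first pair to differ in one place only, and it shows that a five-membered aromatic ring with one hydrogen-bond donor and one hydrogen-bond acceptor and a non-aromatic carbon ring with neither can occupy this position without the two numbers separating. No measured property of either group bears on this step.

Open, as far as these compounds go, is whether another kind of group on this sulfur, such as a longer chain ending in an amine or a carboxylic acid, moves the number beyond the scatter. Among these compounds, also open is whether this step reads the same with the rest of compound 1 changed, as this is the only such pair.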